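A Dihydroxyphenyl in Place of Pyridinyl in Compound 4

A few compounds are considered here, and "the series" means these few. Any claim that something is new, unique, unknown or untested is made for them only; others in the source may bear on it.

Compound 1 `Cc1c(C(=O)N/N=C\c2ccncc2)oc2cccc(O)c12` is the parent of this small series. In a functional assay on PC-3 cells (Homo sapiens) for inhibition (a higher number here means a weaker inhibitor, a lower number a stronger inhibitor), compound 1 gives >= 40000 nM, which is a limit of the assay rather than a number. Among the three measured values, compound 1 alone sits at the limit of >= 40000 nM in this assay, at which 1 of the 3 values shown sits, so its standing is known only as a bound. Compound 2 `Cc1c(C(=O)N/N=C\c2cccc(Br)c2O)oc2cccc(O)c12` gives 16600 nM in this assay, and compound 3 `Cc1c(C(=O)N/N=C\c2cccc(F)c2O)oc2cccc(O)c12` gives 12700 nM. The step of an at least 2.4-fold lower number from compound 1 to compound 2 (0.38 log units; beyond the scatter) and the step of an at least 3.1-fold lower number from compound 1 to compound 3 (0.49 log units; beyond the scatter) both replace the pyridin-4-yl with a substituted 2-hydroxyphenyl, while between compound 2 and compound 3 the step of a 1.3-fold lower number from compound 2 to compound 3 (0.12 log units; within the scatter) lies within the scatter, so the choice of halogen makes no visible difference.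

Compound 4 `Cc1c(C(=O)N/N=C\c2ccc(O)cc2O)oc2cccc(O)c12` has not yet been measured. It differs from compound 1 in one place: 2,4-dihydroxyphenyl in place of pyridin-4-yl on a carbon with a double bond to nitrogen. The two measured steps from compound 1 bear directly on this change, since both move from pyridin-4-yl to a 2-hydroxyphenyl carrying one further substituent; in compound 4 that further substituent is a second hydroxy rather than a halogen. A step of comparable size in the same direction is therefore expected, an at least 3.3-fold lower number from compound 1 to compound 4 (0.52 log units; beyond the scatter). Compound 4 is accordingly estimated at 12000 nM, with a range from 5000 nM to 30000 nM.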

Compound 4, half-maximal inhibitory concentration: 14800 nM
Beside the measured number, compound 4's estimate is 1.2-fold (0.09 log units) below it; measured number inside the range.
By their numbers in this assay, from the lowest: compounds 3, 4 and 2 (each within the scatter of the next). At a limit, above all of these: compound 1.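

Replacing pyridin-4-yl with 2,4-dihydroxyphenyl on the carbon with a double bond to nitrogen again lowers the number in this assay, with an at least 2.7-fold lower number from compound 1 to compound 4 (0.43 log units; beyond the scatter), so the change seen at this position does not depend on a halogen on the ring that enters. The second hydroxy also reads the same as either halogen, with a 1.2-fold higher number from compound 3 to compound 4 (0.07 log units; within the scatter) and a 1.1-fold lower number from compound 2 to compound 4 (0.05 log units; within the scatter), so 3-fluoro-2-hydroxyphenyl, 3-bromo-2-hydroxyphenyl and 2,4-dihydroxyphenyl cannot be told apart in this assay, even though the further group differs in kind and in where it stands on the ring. The step from the parent gives only a bound on the size of this change, because compound 1 stands at a limit of the assay rather than at a number: the limit of >= 40000 nM in this assay, at which 1 of the 4 values shown sits.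

The compounds shown leave open whether the hydroxy at the 2 position of the entering ring is itself what matters, a question that a plain phenyl or a 4-hydroxyphenyl at this place would address. They also leave open how far the further group can vary, for instance whether an amine or a carboxylic acid on the ring would read the same as the hydroxy and the halogens.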